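A few compounds are considered here, and "the series" means these few. Any claim that something is new, unique, unknown or untested is made for them only; others in the source may bear on it.

Of the compounds shown here, three built on one shared core have been measured so far in a functional assay on the whole organism (strain albino) for inhibition, with Rattus norvegicus as the target, read by paw edema, with a stated time of 1 h, at a dose of 0.28 mmol/kg by the oral route; on this read-out higher numbers stand for more inhibition at the one dose given (going by the name of the read-out) and lower numbers for less inhibition. Compound 1 `C=CCn1c(SCC(=O)c2ccccc2)nnc1-c1ccc(OC)c(OC)c1` gives 61%. Compound 2 `CCn1c(SCC(=O)c2ccccc2)nnc1-c1cc(OC)c(OC)c(OC)c1` gives 29%, the lowest of the three numbers, and compound 3 `CCn1c(SC/C(=N/O)c2ccccc2)nnc1-c1cc(OC)c(OC)c(OC)c1` gives 63%. Among the compounds with values here, the one step between compounds that differ in a single place is a number 34 percentage points higher from compound 2 to compound 3 (beyond the scatter); it exchanges the carbonyl-bearing group for an oxime-bearing group on the chain carbon bound to sulfur and tells nothing about methoxy groups on the aromatic ring.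

Compound 4 `CCn1c(SCC(=O)c2ccccc2)nnc1-c1ccc(OC)c(OC)c1` is not yet measured. It differs from compound 2 by hydrogen in place of methoxy on an aromatic carbon. Within the data shown here, no measured step covers this change. Among the measured compounds shown here, the only comparison is compound 1, which also carries two methoxy groups on that ring but differs from compound 2 in a second place as well. Compound 1 nevertheless gives 61%. Compound 4 is therefore expected to give 48%, with a range from 25% to 70%. This estimate means an expected step of a number 19 percentage points higher from compound 2 to compound 4 (beyond the scatter), held with wide uncertainty.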

Compound 4, a percentage reported as inhibition, in the whole organism at one dose (the size of the read-out at that dose, not a potency): 42%
Compound 4: the middle estimate sits 6 percentage points above what was measured; low and high end bracket the measured number.
By their numbers in this assay, from the lowest: compound 2; then compound 4; then compounds 1 and 3 (each within the scatter of the next).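

In this assay, within the data shown here, hydrogen in place of methoxy on the aromatic carbon ortho to a methoxy group gives a number 13 percentage points higher from compound 2 to compound 4 (beyond the scatter), the first direct reading of this position, and in this one pair the third methoxy group goes with the lower number. Among these compounds, compound 4 also gives the first single-place reading of the chain on the aromatic nitrogen: methyl in place of vinyl at its end gives a number 19 percentage points lower from compound 1 to compound 4 (beyond the scatter), so that part of the molecule counts as well as the aromatic ring. Nothing available here explains either step.

From the compounds shown here alone, how a hydroxyl group or a chlorine atom at this aromatic position would compare with hydrogen and methoxy remains open. So does whether the same methoxy-to-hydrogen change would give a similar step with the oxime-bearing chain of compound 3.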